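Pyrrolidine amide caps on the piperidine sulfonamide series

The source may hold more compounds than are shown below. What is called first, only, known or untested is meant among the compounds shown, and "the series" means these compounds.

Compound 1 `O=C(CN1CCNCC1)N1CCC(NS(=O)(=O)c2cc(S(=O)(=O)c3ccccc3)ccc2C(F)(F)F)CC1` gives 140 nM in an assay on isolated protein for binding affinity to secreted frizzled-related protein 1 (Homo sapiens), read by fluorescence; a lower number here means a stronger inhibitor, a higher number a weaker inhibitor. Among the three numbers so far it sits in the middle; compound 3 is nearest a 1.1-fold higher number from compound 1 to compound 3 (0.06 log units; within the scatter) and compound 2 furthest a 1.6-fold lower number from compound 1 to compound 2 (0.19 log units; within the scatter). Compound 2 `O=C1CC[C@@H](C(=O)N2CCC(NS(=O)(=O)c3cc(S(=O)(=O)c4ccccc4)ccc3C(F)(F)F)CC2)N1` gives 90 nM in this assay, and compound 3 `CC(=O)N1CCC[C@H]1C(=O)N1CCC(NS(=O)(=O)c2cc(S(=O)(=O)c3ccccc3)ccc2C(F)(F)F)CC1` gives 160 nM; between them a 1.8-fold higher number from compound 2 to compound 3 (0.25 log units; within the scatter). Compound 4 `CC(C)(C)C(=O)N1CCC[C@H]1C(=O)N1CCC(NS(=O)(=O)c2cc(S(=O)(=O)c3ccccc3)ccc2C(F)(F)F)CC1` carries 1-((tert-butyl)carbonyl)pyrrolidin-2-yl in place of (piperazin-1-yl)methyl on a carbonyl carbon. Among the measured compounds shown here, the steps that bear on this change all swap the same cap for a pyrrolidine-type amide, and none left the scatter, so the step is expected to be small, with no direction claimed beyond the scatter: a 1.1-fold higher number from compound 1 to compound 4 (0.03 log units; within the scatter). Compound 4 is therefore estimated at 150 nM in this assay, with a range of 60 nM to 380 nM.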

Compound 4, half-maximal inhibitory concentration: 40 nM
The estimate for compound 4 lay 3.8-fold (0.57 log units) above the measured number; the measured number lies below the stated range.
By their numbers in this assay, from the lowest: compound 4; then compounds 2, 1 and 3 (each within the scatter of the next).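

Swapping methyl for tert-butyl on the carbonyl carbon of the pyrrolidine amide moves the number in this assay beyond the scatter (a 4.0-fold lower number from compound 3 to compound 4 (0.60 log units; beyond the scatter)), which no earlier step did. Compound 4 also stands apart from the other two caps (a 3.5-fold lower number from compound 1 to compound 4 (0.54 log units; beyond the scatter); a 2.3-fold lower number from compound 2 to compound 4 (0.35 log units; beyond the scatter)), making it the strongest inhibitor of the four. No measurement shown accounts for this gain.

On these data alone, whether isopropyl, cyclopropyl or phenyl in place of tert-butyl would hold this number remains open. The other configuration at the defined stereocentre of the pyrrolidine is also untested in the compounds shown.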